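Trimethoxyphenyl in place of phenylethenyl on the saturated ring carbon

The compounds below may be only part of what the source reports. "The series", "measured", "known", "first", "only" and "open" are said of these compounds alone.

Going by the values given here, compound 2 `Cc1cc(O)c(C2=NN(c3ccc(S(N)(=O)=O)cc3)C(/C=C/c3ccccc3)C2)cc1Cl` gives the highest of the two numbers so far known in a functional assay on UO-31 cells (Homo sapiens) for antiproliferative activity, with a stated time of 48 h (on this read-out higher numbers stand for lower toxicity in this test and lower numbers for higher toxicity in this test), namely 79900 nM. Its nearest neighbour, compound 1 `Cc1cc(O)c(C2=NN(c3ccc(S(N)(=O)=O)cc3)C(c3ccccc3Cl)C2)cc1Cl`, gives 48000 nM in this assay. Among the compounds with values here, the single measured step, a 1.7-fold higher number from compound 1 to compound 2 (0.22 log units; within the scatter), stays within the usual scatter. Compound 3 `COc1ccc(C2CC(c3cc(Cl)c(C)cc3O)=NN2c2ccc(S(N)(=O)=O)cc2)c(OC)c1OC` differs from compound 2 by 2,3,4-trimethoxyphenyl in place of 2-phenylethenyl on a saturated ring carbon. Within the data shown here, no measured step covers this particular exchange; the one step that is known exchanged another group on the same saturated ring carbon and produced only a small shift. On that basis no step beyond the scatter is expected for compound 3 in this assay, and the expected step is a 1.3-fold lower number from compound 2 to compound 3 (0.12 log units; within the scatter). Compound 3 is therefore estimated at 60000 nM, with a range from 20000 nM to 180000 nM.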

Compound 3, concentration lethal to 50% of the cells: > 100000 nM
Compound 3: no number, only a limit (the forecaster's own chance of this, stated with the estimate: 10%); middle value at least 1.6-fold (0.22 log units) away from the limit.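

In this assay, compound 3 gives no number, only a limit of the assay: the limit of > 100000 nM in this assay, at which 1 of the 3 values shown sits. Going by these compounds alone, at this saturated ring carbon, 2,3,4-trimethoxyphenyl in place of 2-chlorophenyl gives an at least 2.0-fold higher number from compound 1 to compound 3 (0.31 log units; beyond the scatter), the first step at this position that is printed as beyond the scatter, so the group on this carbon can shift the read-out towards lower toxicity in this test. 2,3,4-trimethoxyphenyl in place of 2-phenylethenyl gives an at least 1.2-fold higher number from compound 2 to compound 3 (0.09 log units; that floor lies within the scatter), and that floor alone does not set the two groups apart.

From the compounds shown here alone, the full size of both steps remains open, and so does whether a single methoxy group on the phenyl ring would give the same shift as the three of 2,3,4-trimethoxyphenyl. Also open, going by these compounds, is how an amine or a carboxylic acid on this carbon would read in this assay.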